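The source may hold more compounds than are shown below. What is called first, only, known or untested is meant among the compounds shown, and "the series" means these compounds.

Measured compounds and their values:

- Compound 1, `COc1ccc(NC(=O)Nc2cc(C)nc3ccccc23)cc1F`: in an ADME assay on HEK293 cells (Homo sapiens) for cytotoxicity, with a stated time of 72 h (a higher number here means that more compound is needed for the effect, a lower number that less compound is needed), compound 1 gives > 25000 nM, which is a limit of the assay rather than a number.
- Compound 2, `Cc1cc(NC(=O)Nc2cccc(C(N)=O)c2)c2ccccc2n1`: in this assay compound 2 gives > 25000 nM, again a limit.
- Compound 3, `Cc1cc(NC(=O)Nc2ccc(Cl)cc2Cl)c2ccccc2n1`: in this assay compound 3 gives 10000 nM.

Compound 2 stands at the limit of > 25000 nM in this assay, at which 2 of the 3 values shown sit. Among the compounds with values here, nothing more precise than that limit is known for it, so its place among the three can only be described as "at the limit, together with compound 1", while compound 3 is the one compound with a real number.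

The next compound is compound 4, `COc1cccc(NC(=O)Nc2cc(C)nc3ccccc23)c1`. It differs from compound 2 in one place: methoxy in place of carbamoyl on an aromatic carbon. Within the data shown here, compound 1, which also carries a methoxy group, gives only a limit in this assay, and no measured step in this set tells how a carbamoyl-to-methoxy change moves the value. Compound 4 is therefore expected to stay at or near the limit, so the expected step of a number no higher from compound 2 to compound 4 (the limit leaves the size open) is none beyond the usual scatter. For compound 4 the estimate is 25000 nM, with a range from 10000 nM to 60000 nM.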

Compound 4, half-maximal effective concentration: > 25000 nM
Compound 4 was reported as a limit; the forecaster's own chance of this, stated with the estimate: 70%; the middle value sits exactly at the limit.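

Compound 2 and compound 4 both sit at the limit of this assay, so no step can be read between them: the limit of > 25000 nM in this assay, at which 3 of the 4 values shown sit.

The compounds shown leave open whether methoxy in place of carbamoyl changes the value at all, since neither compound has an actual number.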